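The compounds below may be only part of what the source reports. "The series", "measured", "known", "first", "only" and "open" are said of these compounds alone.

Measured so far in an ADME assay on brain (Rattus norvegicus) for protein binding; a higher number here means a larger unbound share of the compound, a lower number a smaller unbound share:
- compound 1 `O=C1O[C@]2(CC[C@H](CNc3ccc(-c4ncccn4)cn3)CC2)CN1c1ccccn1` gives 0.035
- compound 2 `O=C1O[C@]2(CC[C@H](CNc3cnn(-c4ccccc4F)c3)CC2)CN1c1cncnc1` gives 0.044

Compound 1 (0.035) and compound 2 (0.044) lie within the scatter of each other, so neither can be ranked on these numbers. Both show only a small unbound share. The next compound to be read in this assay is compound 3 `O=C1O[C@]2(CC[C@H](CNc3ccc(C(F)(F)F)cn3)CC2)CN1c1ccccn1`. It keeps the core of compound 1 and carries trifluoromethyl in place of pyrimidin-2-yl on an aromatic carbon. The group sits on a six-membered aromatic ring with 1 nitrogen, two atoms from the ring nitrogen.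

Among the measured compounds shown here, no step between measured compounds is available, so the series offers no direct guide to this replacement. The expectation rests on the two close values alone, and it is held loosely. A small rise is the expected direction, with no step beyond the scatter: the estimated change is a 1.1-fold higher number from compound 1 to compound 3 (0.06 log units; within the scatter). Compound 3 is estimated at 0.04 with an expected range of 0.02 to 0.08.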

Compound 3, unbound fraction: 0.005
Beside the measured number, compound 3's estimate is 8.0-fold (0.90 log units) above it; measured number below the stated range.
By their numbers in this assay, from the lowest: compound 3; then compounds 1 and 2 (each within the scatter of the next).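

Among the compounds shown here, at this position, on an aromatic carbon of a six-membered aromatic ring with 1 nitrogen, two atoms from the ring nitrogen and para to a large group, this assay responds clearly to the group carried: trifluoromethyl in place of pyrimidin-2-yl gives a 7.0-fold lower number from compound 1 to compound 3 (0.85 log units; beyond the scatter), the first single-place change and one that lies beyond the scatter, whereas the two earlier compounds differ in more than one place and could not be ranked. The change also has several parts, since a six-membered aromatic ring with 2 hetero atoms and 2 hydrogen-bond acceptors leaves while 3 fluorine atoms on a single carbon enter, with no ring and no acceptor, so this one step cannot assign the drop to any single part of the swap. No measurement at hand bears on the cause of this step.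

Still open, on these data alone, is whether a phenyl ring, a methyl group or a nitrile at this position would stay near compound 1 or fall toward compound 3, which would begin to separate the ring from the fluorine atoms. Also open, as far as these compounds go, is whether the step carries over to other groups on the far side of the shared core, such as the pyrimidin-5-yl group of compound 2.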